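Isopropoxycarbonyl for isopropylsulfonyl on the ring amine nitrogen

The source may hold more compounds than are shown below. What is called first, only, known or untested is meant among the compounds shown, and "the series" means these compounds.

Measured so far:
Compound 1 `O=C(CCCC1CCN(C(=O)CCc2ccccc2)CC1)c1ncco1` gives 22 nM in an assay on isolated protein for inhibition of Fatty-acid amide hydrolase 1 (Homo sapiens); a higher number here means a weaker inhibitor, a lower number a stronger inhibitor.
Compound 2 `CC(C)S(=O)(=O)N1CCC(CCCC(=O)c2ncco2)CC1` gives 140 nM in this assay.

Compound 2 holds the highest number of the two in this assay; its nearest neighbour is compound 1, whose number lies well outside the scatter and on the lower side. Among the compounds with values here, no single-change step between measured compounds is available, so the two values only show that the phenylpropanoyl group on the ring nitrogen goes with the stronger inhibition and the isopropylsulfonyl group with the weaker.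

Compound 3 `CC(C)OC(=O)N1CCC(CCCC(=O)c2ncco2)CC1` keeps everything of compound 2 except the group on the ring nitrogen: isopropoxycarbonyl in place of isopropylsulfonyl on an amine nitrogen in a ring. The carbonyl-bearing carbamate sits where a carbonyl-bearing amide sits in compound 1, and compound 1 reads lower than compound 2. On that basis the step of a 2.8-fold lower number from compound 2 to compound 3 (0.45 log units; beyond the scatter) is expected to run toward a lower number, of moderate size and beyond the scatter. For compound 3 the expected value in this assay is 50 nM, with a likely range from 15 nM to 200 nM.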

Compound 3, half-maximal inhibitory concentration: 4 nM
Beside the measured number, compound 3's estimate is 13-fold (1.10 log units) above it, outside the stated range (below it).
By their numbers in this assay, from the lowest: compound 3; then compound 1; then compound 2.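

In this assay the group on the ring nitrogen proves to be a strong determinant of the read-out: with the rest of the structure held fixed, isopropoxycarbonyl in place of isopropylsulfonyl gives a 35-fold lower number from compound 2 to compound 3 (1.54 log units; beyond the scatter), although both groups have 6 heavy atoms and 2 hydrogen-bond acceptors. Isopropoxy in place of phenethyl on a carbonyl carbon gives a 5.5-fold lower number from compound 1 to compound 3 (0.74 log units; beyond the scatter), so the phenethyl group is not required for a low number in this series. Nothing measured here bears on the cause of either step.

The compounds shown do not separate the contribution of the carbamate oxygen from that of the isopropyl group, which a plain isobutyryl amide or a dimethylaminocarbonyl urea on the same ring nitrogen could test. From the compounds shown here alone, it also remains open how far the alkyl part of the carbamate can change, for example to tert-butyl or cyclohexyl, and whether the low number of compound 3 would hold with a shorter or longer chain leading to the ketone.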